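A few compounds are considered here, and "the series" means these few. Any claim that something is new, unique, unknown or untested is made for them only; others in the source may bear on it.

Measured so far in an ADME assay on MCF7 cells (Homo sapiens) for cytotoxicity, with a stated time of 72 h; on this read-out higher numbers stand for weaker inhibition and lower numbers for stronger inhibition:
- Compound 1 `COc1ccccc1CNc1ncnc2c1ncn2C1CCCCO1`: > 100000 nM (a limit)
- Compound 2 `COc1ccc(OC)c(CNc2ncnc3c2ncn3C2CCCCO2)c1`: 25400 nM
- Compound 3 `COc1ccccc1CNc1ncnc2c1ncn2C1CCCO1`: > 100000 nM (a limit)

Compound 3 has no number of its own on this assay, since it sits at the limit of > 100000 nM in this assay, at which 2 of the 3 values shown sit. Putting oxolan-2-yl in place of oxan-2-yl on an aromatic nitrogen gave a step that the two limits leave unreadable from compound 1 to compound 3, so that exchange offers no guide to size.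

Compound 4 `COc1ccc(OC)c(CNc2ncnc3c2ncn3C2CCCO2)c1` departs from compound 3 by a single change: methoxy in place of hydrogen on an aromatic carbon. In words, it is methoxy in place of hydrogen on an aromatic carbon.

Within the data shown here, one measured step bears directly on this, the same exchange made with oxan-2-yl on the aromatic nitrogen: an at least 3.9-fold lower number from compound 1 to compound 2 (0.59 log units; beyond the scatter). That step is beyond the scatter, and it brought compound 2 to a measured 25400 nM. It is a single precedent, and the starting point of the step is itself a limit, so its full size is not known. A step of similar kind, toward a lower number, is therefore expected here, though compound 4 may yet stay at the limit. The expected step is an at least 3.3-fold lower number from compound 3 to compound 4 (0.52 log units; beyond the scatter). For compound 4 the estimated value is 30000 nM, within an expected range of 10000 nM to 90000 nM.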

Compound 4, half-maximal inhibitory concentration: > 50000 nM
Compound 4 gave a limit, no number; the forecaster's own chance of this, stated with the estimate: 20%; middle value at least 1.6-fold (0.22 log units) away from the limit.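

Compound 4 has no number of its own in this assay, only a limit: the limit of > 50000 nM in this assay, at which 1 of the 4 values shown sits.

The step between compound 3 and compound 4 cannot be read, so the methoxy on the aromatic carbon, para to a methoxy group, has no measured size when oxolan-2-yl sits on the aromatic nitrogen, and the lower number seen with oxan-2-yl finds no confirmation here. Among these compounds, with that methoxy in place, the exchange of oxan-2-yl for oxolan-2-yl on the aromatic nitrogen gave an at least 1.9-fold higher number from compound 2 to compound 4 (0.29 log units; that floor lies within the scatter), which gives this exchange a readable floor for the first time, though a floor of that size does not by itself establish a change.

From the compounds shown here alone, whether the methoxy lowers the number at all with oxolan-2-yl on the aromatic nitrogen remains open, as does the true size of the exchange between the two groups on that nitrogen. Also open, going by these compounds, is what an amine, a carboxylic acid or a longer chain in place of this methoxy would do in this assay.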